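A few compounds are considered here, and "the series" means these few. Any claim that something is new, unique, unknown or untested is made for them only; others in the source may bear on it.

Measured compounds:
compound 1, `COc1cccc(OCCC(C)(C)C)c1C(=O)/C=C/c1ccc(O)cc1`, > 30000 nM
compound 2, `O=C(/C=C/c1ccc(O)cc1)c1c(O)cccc1OCC1CCCC1`, 3160 nM
compound 3, `CC(C)(C)CCOc1cccc(O)c1C(=O)/C=C/c1ccc(S(N)(=O)=O)cc1`, 2950 nM

In a functional assay on NCI-H23 cells (Homo sapiens) for antiproliferative activity, read by sulforhodamine B assay (on this read-out lower numbers stand for stronger inhibition of growth and higher numbers for weaker inhibition of growth), compound 2 gives 3160 nM, the highest of the two numbers shown. Compound 3 gives 2950 nM, within the usual scatter of the value of compound 2. For compound 1 the value > 30000 nM is a limit of the assay rather than a number (the limit of > 30000 nM in this assay, at which 1 of the 3 values shown sits).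

Compound 4, `CCCCOc1cccc(O)c1C(=O)/C=C/c1ccc(O)cc1`, has not yet been measured. It differs from compound 2 in one place: propyl in place of cyclopentyl on a saturated chain carbon bound to an oxygen on an aromatic ring.

Among the compounds with values here, no step between two measured compounds is known, so there is little to lean on. The chains in compound 2 and compound 3 differ yet their values sit together, so compound 4 is expected to move from compound 2 by a 1.6-fold higher number from compound 2 to compound 4 (0.20 log units; within the scatter), a small shift toward weaker inhibition that may stay within the scatter. Compound 4 is estimated at 5000 nM, between 1500 nM and 15000 nM.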

Compound 4, concentration for 50% growth inhibition: > 30000 nM
Compound 4 was reported as a limit; the forecaster's own chance of this, stated with the estimate: 10%; middle value at least 6.0-fold (0.77 log units) from the limit.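

Replacing cyclopentyl with propyl on a saturated chain carbon bound to an oxygen on an aromatic ring gives an at least 9.4-fold higher number from compound 2 to compound 4 (0.97 log units; beyond the scatter) in this assay. Within the data shown here, this is the first single-place step available, and it shows that the group at this place can strongly change growth inhibition. The full size of the step is unknown, because compound 4 gives only a limit of the assay: the limit of > 30000 nM in this assay, at which 2 of the 4 values shown sit.

As far as these compounds go, it remains open whether the ring itself matters or simply the size of the group. A cyclohexyl group, a longer chain such as hexyl, or an amine on the chain could help separate these possibilities.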